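This account rests on a few compounds, and the source may have more. Where it says the series, first, only, none or still open, it means among the compounds named here.

Compound 1 `Oc1ccc(-c2cncc(-c3cc4ccc(O)cc4[nH]3)n2)cc1` and compound 2 `CS(=O)(=O)c1ccc(-c2cncc(-c3cc4ccc(O)cc4[nH]3)n2)cc1` share one core; compound 3 `Oc1ccc(-c2cncc(-c3cc4cc(O)ccc4[nH]3)n2)cc1` and compound 4 `CS(=O)(=O)c1ccc(-c2cncc(-c3cc4cc(O)ccc4[nH]3)n2)cc1` share another. The difference between the two cores is not broken down here. In a functional assay on Caco-2 cells (Homo sapiens) for cytotoxicity, with a stated time of 48 h (on this read-out higher numbers stand for weaker inhibition and lower numbers for stronger inhibition), compound 1 gives 7000 nM, and compound 2 gives 13000 nM. The change between these two is methylsulfonyl in place of hydroxy on an aromatic carbon, and it made a 1.9-fold higher number from compound 1 to compound 2 (0.27 log units; within the scatter). In this assay compound 3 gives 3000 nM, the lowest of the three numbers and beyond the scatter from both compound 1 and compound 2. Compound 4 is not yet measured in this assay. For the measured compounds named here, it differs from compound 3 as methylsulfonyl in place of hydroxy on an aromatic carbon, the same change, at the same place, as the one from compound 1 to compound 2; among the compounds here this change occurs twice and has been measured once. Going by the values given here, the expected step is a 1.9-fold higher number from compound 3 to compound 4 (0.28 log units; within the scatter), resting on the single measured instance of this change, because it gave a 1.9-fold higher number from compound 1 to compound 2 (0.27 log units; within the scatter), a step within the scatter. Compound 4 is therefore estimated to give 5700 nM in this assay, with a likely range from 2500 nM to 13000 nM.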

Compound 4, half-maximal inhibitory concentration: 3000 nM
Compound 4: middle estimate off by 1.9-fold (0.28 log units), on the high side; the range from low to high includes it.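

Methylsulfonyl in place of hydroxy on an aromatic carbon gave no change at the digits printed from compound 3 to compound 4 (within the scatter) on the second core in this assay and sits close to the step on the first core, so the two instances do not separate: the same change on two cores in this assay, a 1.9-fold higher number (0.27 log units; within the scatter) from compound 1 to compound 2 and no change at the digits printed (within the scatter) from compound 3 to compound 4, 1.9-fold (0.27 log units) apart, within the scatter of two such steps.
Within this pair of cores, the change can be carried from one to the other without a detectable difference in size of step. This does not show that the change moves the read-out on either core, since both steps lie within the scatter, and two pairs in one assay say nothing about any further core.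

The compounds shown leave open whether an amine, a carboxylic acid or a longer chain on the same aromatic carbon, para to a large group, would give a step beyond the scatter on either core. They also leave open whether such a step would have the same size on both cores.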